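Swapping methoxy for 3-hydroxypropyl at the assay limit

A few compounds are considered here, and "the series" means these few. Any claim that something is new, unique, unknown or untested is made for them only; others in the source may bear on it.

Compound 2 `COc1ccc2c(c1)NC(=O)Nc1cnc(C#N)c(n1)OCCCCCO2` gives > 10000 nM in a functional assay on NCI-H1299 cells (Homo sapiens), read by flow cytometry (a higher number here means that more compound is needed for the effect, a lower number that less compound is needed), which is a limit and not a number. Compound 1 `N#Cc1ncc2nc1OCC/C=C\COc1ccc(O)cc1NC(=O)N2` gives > 10000 nM, also a limit. Compound 3 `N#Cc1ncc2nc1OCC/C=C\COc1ccc(CCCOC3CCCCO3)cc1NC(=O)N2` gives > 10000 nM, again a limit. The whole picture so far is therefore (the limit of > 10000 nM in this assay, at which 3 of the 3 values shown sit).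

Compound 4 `N#Cc1ncc2nc1OCCCCCOc1ccc(CCCO)cc1NC(=O)N2` differs from compound 2 as follows: 3-hydroxypropyl in place of methoxy on an aromatic carbon. In words, 3-hydroxypropyl stands in place of methoxy on an aromatic carbon.

Within the data shown here, only one measured step bears on this change, since it also places a propyl chain on an aromatic carbon: a step that the two limits leave unreadable from compound 1 to compound 3. It has no readable size, so it offers no direction and no magnitude to carry over. The expectation is thus for little or no movement in this assay, and compound 4 may well return only a limit too.

The expected change is an at least 1.2-fold lower number from compound 2 to compound 4 (0.09 log units; that floor lies within the scatter).

For compound 4 the estimated value is 8000 nM, with an expected range of 1500 nM to 30000 nM.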

Compound 4, half-maximal effective concentration: > 10000 nM
Compound 4 gave a limit, no number; the forecaster's own chance of this, stated with the estimate: 60%; at least 1.2-fold (0.09 log units) between middle value and limit.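

The step from compound 2 to compound 4 cannot be read, because both give only a limit, as do all the compounds shown: the limit of > 10000 nM in this assay, at which 4 of the 4 values shown sit. The compounds shown leave open whether any of these changes to the shared core moves this assay at all.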